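A few compounds are considered here, and "the series" means these few. Any claim that something is new, unique, unknown or untested is made for them only; others in the source may bear on it.

Measured compounds in a functional assay on HL-60 cells (Homo sapiens) for antiproliferative activity, read by MTT assay; on this read-out lower numbers stand for stronger inhibition and higher numbers for weaker inhibition:
- compound 2 `CCC[C@@H]1O[C@H](COCc2ccccc2)[C@@H](OCc2ccccc2)[C@H](OCc2ccccc2)[C@H]1O`: 11700 nM
- compound 3 `CCC[C@H]1O[C@H](COCc2ccccc2)[C@@H](OCc2ccccc2)[C@H](OCc2ccccc2)[C@H]1O`: 28200 nM
- compound 1 `CCC[C@H]1O[C@H](COCc2ccccc2)[C@H](OCc2ccccc2)[C@H](OCc2ccccc2)[C@H]1O`: "not active" (no number reported) (no number reported)

Compound 2 holds the lowest of the two reported numbers; its nearest neighbour is compound 3, with a 2.4-fold higher number from compound 2 to compound 3 (0.38 log units; beyond the scatter). That step rests on a single configurational difference, as the two compounds are otherwise identical (the fact that compounds 2 and 3 differ only in the configuration as drawn). Compound 1 likewise differs from compound 2 and from compound 3 only in configuration the fact that compounds 1 and 2 differ only in the configuration as drawn (the fact that compounds 1 and 3 differ only in the configuration as drawn), yet gives no number at all.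

Compound 4 `CC[C@@H]1O[C@H](COCc2ccccc2)[C@@H](OCc2ccccc2)[C@H](OCc2ccccc2)[C@H]1O` is the next entry. Relative to compound 2 the change is hydrogen in place of methyl on a saturated chain carbon, two bonds along the chain from a saturated ring carbon. Among the compounds with values here, none of the measured steps touches the chain: all three concern configuration at ring carbons, and no shortening of the propyl chain has been tried in this set. Within the data shown here, the only steps in hand are modest, and a one-carbon trim of a side chain at the edge of the core gives no reason from these data to expect movement beyond the scatter in this assay. Compound 4 is therefore expected near compound 2, with a 1.2-fold higher number from compound 2 to compound 4 (0.08 log units; within the scatter) as the estimated step, allowing for a slight drift toward weaker inhibition. The estimate for compound 4 is 14000 nM, within 6000 nM to 35000 nM.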

Compound 4, half-maximal inhibitory concentration: 8200 nM
The estimate for compound 4 lay 1.7-fold (0.23 log units) above the measured number; low and high end bracket the measured number.
By their numbers in this assay, from the lowest: compounds 4 and 2 (each within the scatter of the next); then compound 3.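

In this assay, propyl to ethyl gives a 1.4-fold lower number from compound 2 to compound 4 (0.15 log units; within the scatter), so this one-carbon trim on the chain leaves no readable shift within this pair. Within the data shown here, this is the first view of the chain rather than the configuration of the shared core, and the step stands in contrast to the configurational one, a 2.4-fold higher number from compound 2 to compound 3 (0.38 log units; beyond the scatter), which lies beyond the scatter. The information on hand concerns configuration only and offers no explanation for the chain result.

As far as these compounds go, whether the chain stays this permissive with a longer chain such as butyl, or with an amine or a carboxylic acid in place of propyl, remains open. Also open, from the compounds shown here alone, is whether the configurational difference seen with the propyl chain carries over to compounds with the ethyl chain.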